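Series notes: tolerated concentration, compounds 1 to 4

A few compounds are considered here, and "the series" means these few. Any claim that something is new, unique, unknown or untested is made for them only; others in the source may bear on it.

Measured so far in an ADME assay on HEL cells (Homo sapiens) for cytotoxicity; a higher number here means that more compound is tolerated, a lower number that less compound is tolerated:
Compound 1, `O=C(COc1cccc2ccccc12)N/N=C/c1ccc(O)cc1`: compound 1 gives 20 ug/mL
Compound 2, `C/C(=N\NC(=O)COc1cccc2ccccc12)c1cccc([N+](=O)[O-])c1`: compound 2 gives 20 ug/mL
Compound 3, `C/C(=N\NC(=O)COc1cccc2ccccc12)c1ccccc1`: compound 3 gives 20 ug/mL

Compound 3 stands level with compounds 1 and 2 in this assay; all three values sit within the scatter of one another, so no order can be read among them. Among the compounds with values here, the only single-point step in hand is no change at the digits printed from compound 2 to compound 3 (within the scatter), and it left the read-out unchanged within the scatter. Compound 4, `C/C(=N\NC(=O)COc1cccc2ccccc12)c1ccc([N+](=O)[O-])cc1`, is not yet measured. From compound 3 to compound 4 the change is nitro in place of hydrogen on an aromatic carbon. Within the data shown here, this is the one measured step run in reverse, with the nitro group now on a different aromatic carbon of the same six-membered aromatic ring of carbon only; nothing among compounds 1, 2 and 3 points to a nitro group at any place on this ring moving the read-out. Compound 4 is therefore expected to sit level with compound 3, a step of no change at the digits printed from compound 3 to compound 4 (within the scatter). The estimate for compound 4 is 20 ug/mL, with a range from 10 ug/mL to 40 ug/mL.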

Compound 4, minimum cytotoxic concentration: 100 ug/mL
Beside the measured number, compound 4's estimate is 5.0-fold (0.70 log units) below it; the measured number lies above the stated range.
By their numbers in this assay, from the lowest: compounds 1, 2 and 3 (each within the scatter of the next); then compound 4.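

In this assay, nitro in place of hydrogen on an aromatic carbon, para to a large group, gives a 5.0-fold higher number from compound 3 to compound 4 (0.70 log units; beyond the scatter). The earlier step, no change at the digits printed from compound 2 to compound 3 (within the scatter), showed no sign of this, and 4-nitrophenyl in place of 3-nitrophenyl now gives a 5.0-fold higher number from compound 2 to compound 4 (0.70 log units; beyond the scatter). Among compounds 2, 3 and 4, the read-out therefore depends on where the nitro group sits on the ring, and its presence alone does not set the number.

On these data alone, whether an amine, a carboxylic acid or a methoxy group at this same place would also raise the tolerated concentration remains open, so the step cannot yet be tied to nitro in particular. No measurement in hand bears on what lies behind the step.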